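Removing a Fluorine from a Weak Receptor Binder

The source may report more compounds than this note shows. Statements on the series, on what has been measured and on what is new or still open speak of the compounds shown alone.

Compound 1, `CS(=O)(=O)c1ccc(C(=O)NCC(=O)N(Cc2ccccc2)Cc2ccccc2)cc1[N+](=O)[O-]`: 3600 nM
Compound 2, `CN(CC(=O)N1CCN(c2ccc(F)cc2)CC1)C(=O)c1ccc(S(C)(=O)=O)c([N+](=O)[O-])c1`: > 60000 nM
Compound 3, `CS(=O)(=O)c1ccc(C(=O)NCC(=O)N2CCCCC2)cc1[N+](=O)[O-]`: > 60000 nM

Of the compounds shown here, three sharing the same core have been tested in an assay on isolated protein for inhibition of thyroid hormone receptor beta (Homo sapiens), read by fluorescence polarization; a higher number here means a weaker inhibitor, a lower number a stronger inhibitor. Compound 1 gives a measured number, 3600 nM. Compound 2 gives no number at all, only a limit, > 60000 nM, meaning the assay could not resolve any inhibition within its working range. Compound 3 likewise reaches only a limit, > 60000 nM. Compound 2 therefore stands at the weak end of what has been seen so far, sitting at the limit of > 60000 nM in this assay, at which 2 of the 3 values shown sit, rather than on a real value.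

Compound 4, `CN(CC(=O)N1CCN(c2ccccc2)CC1)C(=O)c1ccc(S(C)(=O)=O)c([N+](=O)[O-])c1`, has not yet been measured in this assay. It differs from compound 2 by hydrogen in place of fluoro on an aromatic carbon. For the measured compounds named here, no pair of measured compounds shows this same change, so there is no measured step to lean on. A single fluorine removed on a ring far from the rest of the molecule is a small change, and the expectation is a step from compound 2 to compound 4 in this assay of a step that the limit leaves unreadable from compound 2 to compound 4, no more than the usual scatter. Compound 4 is thus expected to give about 80000 nM, within a range from 20000 nM to 300000 nM, most likely reported again only as a limit.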

Compound 4, half-maximal inhibitory concentration: > 60000 nM
Compound 4: no number, only a limit (the forecaster's own chance of this, stated with the estimate: 75%); the middle value is on the limit's open side.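

Compound 2 and compound 4 each reach only a limit, so no step between them can be read, and the change from 4-fluorophenyl to phenyl has no visible size here: the limit of > 60000 nM in this assay, at which 3 of the 4 values shown sit.

The compounds shown leave open whether this same change would shift the result in a compound strong enough to give a measured number.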